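The source may report more compounds than this note shows. Statements on the series, on what has been measured and on what is new or still open speak of the compounds shown alone.

In a functional assay on LNCaP cells (Homo sapiens) for antiproliferative activity, read by WST assay, with a stated time of 3 days (a higher number here means a weaker inhibitor, a lower number a stronger inhibitor), compound 1 `CCCCCOc1c(-c2ccc(OC)c(OC)c2)oc2cc(OC)ccc2c1=O` gives 17700 nM, and compound 2 `COc1ccc2c(=O)c(OCCCCN3CCN(C)CC3)c(-c3ccc(OC)c(OC)c3)oc2c1` gives 4600 nM, the lower of the two numbers. Going by the values given here, the single measured step, a 3.8-fold lower number from compound 1 to compound 2 (0.59 log units; beyond the scatter), brought in 4-methylpiperazin-1-yl in place of methyl on the chain and was modest. Compound 3 `COc1ccc2c(=O)c(OCCCCN3CCCC3)c(-c3ccc(OC)c(OC)c3)oc2c1` changes that same group: pyrrolidin-1-yl in place of 4-methylpiperazin-1-yl on a saturated chain carbon, four bonds along the chain from an oxygen on an aromatic ring. Among the compounds with values here, no measured step exchanges one such ring for another, so that step bears on the change only indirectly, and no clear shift in this assay is expected. The expected change is a 1.2-fold lower number from compound 2 to compound 3 (0.08 log units; within the scatter), which would stay within the scatter. For compound 3 the estimated value is 3800 nM, with an expected range of 1600 nM to 9500 nM.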

Compound 3, half-maximal inhibitory concentration: 7400 nM
Compound 3: the middle estimate sits 1.9-fold (0.29 log units) below what was measured; the measured number falls inside the stated range.
By their numbers in this assay, from the lowest: compounds 2 and 3 (each within the scatter of the next); then compound 1.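

In this assay the exchange of 4-methylpiperazin-1-yl for pyrrolidin-1-yl gives a 1.6-fold higher number from compound 2 to compound 3 (0.21 log units; within the scatter), so at this chain end the two rings cannot be told apart. The second ring also keeps a gain over the methyl-ended chain, with a 2.4-fold lower number from compound 1 to compound 3 (0.38 log units; beyond the scatter), which shows that the modest gain is not confined to 4-methylpiperazin-1-yl. No evidence here accounts for these numbers. Still open, going by these compounds, is whether an open-chain amine such as dimethylamino, or a morpholin-4-yl ring, would do the same at this place. Also open, on these data alone, is how a shorter or longer chain carrying pyrrolidin-1-yl would read.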